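Changing the Triazole Substituent: Cytotoxicity on Pancreatic Cancer Cells

The compounds below may be only part of what the source reports. "The series", "measured", "known", "first", "only" and "open" are said of these compounds alone.

Measured compounds:
Compound 1 `COc1nc2ccc(Br)cc2cc1C(c1ccccc1)n1cc(CO)nn1` gives 15% in an ADME assay on PANC-1 cells (Homo sapiens) for cytotoxicity, read by sulforhodamine B assay, with a stated time of 48 h, tested at 10 uM; a lower number here means less inhibition, a higher number more inhibition at the concentration tested (going by the name of the read-out).
Compound 2 `COc1nc2ccc(Br)cc2cc1C(c1ccccc1)n1cc(-c2ccccc2C(F)(F)F)nn1` gives 11.4% in this assay.

Within the data shown here, compound 2 holds the lower of the two numbers so far, but the only measured step, a number 3.6 percentage points lower from compound 1 to compound 2 (within the scatter), lies within the scatter, so the two compounds cannot be ranked against each other. Compound 3 `COc1nc2ccc(Br)cc2cc1C(c1ccccc1)n1cc(C2CC2)nn1` is the next member of this series and has not yet been measured in this assay. Its change from compound 2 is cyclopropyl in place of 2-(trifluoromethyl)phenyl on an aromatic carbon. Among the measured compounds shown here, the one step available for comparison is the exchange of hydroxymethyl for 2-(trifluoromethyl)phenyl at this same aromatic carbon, which produced a number 3.6 percentage points lower from compound 1 to compound 2 (within the scatter), a change within the scatter. For the measured compounds named here, with only that step to draw on, and with it showing no movement beyond the scatter, the expectation for the exchange of 2-(trifluoromethyl)phenyl for cyclopropyl is likewise a step of no clear size in either direction, a number 1.6 percentage points higher from compound 2 to compound 3 (within the scatter). Compound 3 is therefore estimated at 13%, with a range from 2% to 26%.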

Compound 3, a percentage reported as inhibition, at one concentration (the size of the read-out at that concentration, not a potency): 21.8%
Compound 3: middle estimate off by 8.8 percentage points, on the low side; measured number inside the range.
By their numbers in this assay, from the lowest: compounds 2, 1 and 3 (each within the scatter of the next, the first and the last beyond it).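

In this assay, this aromatic carbon now shows its first step beyond the scatter: cyclopropyl in place of 2-(trifluoromethyl)phenyl gives a number 10.4 percentage points higher from compound 2 to compound 3 (beyond the scatter), so the group held here can move the read-out, if only modestly. The same cyclopropyl in place of hydroxymethyl gives a number 6.8 percentage points higher from compound 1 to compound 3 (within the scatter), which lies within the scatter, so compound 1 and compound 3 cannot be ranked, and only compound 2 and compound 3 stand apart. No measurement at hand explains why the exchange of 2-(trifluoromethyl)phenyl for cyclopropyl moves the number.

This exchange alters several things at once, replacing 10 heavy atoms with 3 and a six-membered aromatic ring with a three-membered non-aromatic ring, so the compounds shown cannot say which of these differences goes with the step. A plain phenyl or a cyclohexyl at this carbon would begin to separate ring size from aromatic character and from the trifluoromethyl group, while an amine or a carboxylic acid would test a kind of group quite unlike any of the three shown here.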